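Swapping methoxy for methylsulfanyl on compound 3

The compounds below may be only part of what the source reports. "The series", "measured", "known", "first", "only" and "open" are said of these compounds alone.

Measured so far in a functional assay on NCI-H727 cells (Homo sapiens) for cytotoxicity, with a stated time of 48 h; on this read-out higher numbers stand for weaker inhibition and lower numbers for stronger inhibition:
- compound 1 `COc1cc(OC)c(C(=O)/C=C/c2ccccc2OC)c(OC)c1` gives 4000 nM
- compound 2 `COc1cc(OC)c(C(=O)/C=C/c2ccccc2SC)c(OC)c1` gives 8700 nM
- compound 3 `COc1cc(O)c(C(=O)/C=C/c2ccccc2OC)c(OC)c1` gives 11000 nM

Compound 3 and compound 2 stand within the usual scatter of each other, and both numbers lie above that of compound 1. The series shows a 2.8-fold higher number from compound 1 to compound 3 (0.44 log units; beyond the scatter), a modest step. That step is a different change from the one at issue here.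

Compound 4 `COc1cc(O)c(C(=O)/C=C/c2ccccc2SC)c(OC)c1` differs from compound 3 by methylsulfanyl in place of methoxy on an aromatic carbon, ortho to a large group. The same exchange has been measured once, as a 2.2-fold higher number from compound 1 to compound 2 (0.34 log units; beyond the scatter), and that step is also modest. The expectation therefore rests on a single pair, with nothing yet showing whether the exchange behaves alike in compound 3.

The step expected in this assay is a 2.0-fold higher number from compound 3 to compound 4 (0.30 log units; within the scatter), modest and toward a higher number, as in the measured exchange. The estimate for compound 4 is 22000 nM, with 10000 nM to 48000 nM as the expected range.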

Compound 4, half-maximal inhibitory concentration: 9000 nM
Estimate against measurement, compound 4: 2.4-fold (0.39 log units) above; the measured number lies below the stated range.
By their numbers in this assay, from the lowest: compound 1; then compounds 2, 4 and 3 (each within the scatter of the next).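

In this assay, methylsulfanyl in place of methoxy on an aromatic carbon, ortho to a large group, gives a 1.2-fold lower number from compound 3 to compound 4 (0.09 log units; within the scatter), so the exchange does not reach beyond the scatter on this core, although the two steps themselves cannot be told apart: the same change on two cores in this assay, a 2.2-fold higher number (0.34 log units; beyond the scatter) from compound 1 to compound 2 and a 1.2-fold lower number (0.09 log units; within the scatter) from compound 3 to compound 4, 2.7-fold (0.42 log units) apart, within the scatter of two such steps

Hydrogen in place of methyl on an oxygen on an aromatic ring gives a 1.0-fold higher number from compound 2 to compound 4 (0.01 log units; within the scatter), and the same caution holds: the same change on two cores in this assay, a 2.8-fold higher number (0.44 log units; beyond the scatter) from compound 1 to compound 3 and a 1.0-fold higher number (0.01 log units; within the scatter) from compound 2 to compound 4, 2.7-fold (0.42 log units) apart, within the scatter of two such steps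

Among these four compounds, each change gives a step beyond the scatter only when made on compound 1, and neither does so once the other change is already present.

Going by these compounds, whether an amine or a longer chain such as ethoxy in place of methoxy at this position would behave like methylsulfanyl remains open. Within the data shown here, each change rests on only two pairs, so whether this behaviour extends beyond these compounds also remains open.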